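Silyl ether at the ring hydroxyl: cytotoxicity outlook

The source may hold more compounds than are shown below. What is called first, only, known or untested is meant among the compounds shown, and "the series" means these compounds.

Compound 2 `Cc1cn([C@@H]2O[C@H](COC(=O)c3ccccc3)[C@@]3(OS(=O)(=O)C=C3NC(=O)NC(=O)c3ccccc3)[C@H]2O)c(=O)n(C)c1=O` stands only at a limit in an ADME assay on HEL cells (Homo sapiens) for cytotoxicity, with a stated time of 3 days; on this read-out lower numbers stand for higher toxicity in this test and higher numbers for lower toxicity in this test: here compound 2 gives > 100000 nM, a limit and not a number. Compound 1 `Cc1cn([C@@H]2O[C@H](CO[Si](C)(C)C(C)(C)C)[C@@]3(OS(=O)(=O)C=C3NC(=O)NC(=O)c3ccccc3)[C@H]2O[Si](C)(C)C(C)(C)C)c(=O)n(C)c1=O` also sits at a limit, giving >= 80000 nM in this assay. Compound 3 `Cc1cn([C@@H]2O[C@H](COC(=O)c3ccccc3)[C@@]3(OS(=O)(=O)C=C3NC(=O)NC(=O)c3ccccc3)[C@H]2O[Si](C)(C)C(C)(C)C)c(=O)n(C)c1=O` carries a group of 7 heavy atoms (6 carbon, 1 silicon; no ring) in place of a hydrogen atom, on an oxygen on a saturated carbon. Within the data shown here, no measured step exists; since compound 1 at the limit of >= 80000 nM in this assay, at which 1 of the 2 values shown sits, also shows no toxicity within range, no step beyond the scatter is expected for compound 3, the estimated step being a number no higher from compound 2 to compound 3 (the limit leaves the size open). For compound 3 the expected value in this assay is 100000 nM, in the range 40000 nM to 250000 nM.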

Compound 3, minimum cytotoxic concentration: >= 5000 nM
Compound 3 gave a limit, no number; the forecaster's own chance of this, stated with the estimate: 70%; the middle value does not contradict the limit.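

In this assay, among these compounds, compound 1, compound 2 and compound 3 all stand at limits, so no step to compound 3 can be read. From the compounds shown here alone, whether the group of 7 heavy atoms (6 carbon, 1 silicon; no ring) in place of a hydrogen atom shifts the read-out at all stays open.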